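Swapping back to a methylpiperazine amide on a longer chain

The source may hold more compounds than are shown below. What is called first, only, known or untested is meant among the compounds shown, and "the series" means these compounds.

Values measured in a functional assay on MCF7 cells (Homo sapiens) for antiproliferative activity, read by sulforhodamine B assay, with a stated time of 48 h; on this read-out lower numbers stand for stronger inhibition and higher numbers for weaker inhibition:
- compound 1 `COc1ccc(-c2oc3c(OC)c(OC)cc(OCCCC(=O)N4CCN(C)CC4)c3c(=O)c2O)cc1` gives > 40000 nM (a limit of the assay, not a number)
- compound 2 `CCCCN(C)C(=O)CCCCOc1cc(OC)c(OC)c2oc(-c3ccc(OC)cc3)c(O)c(=O)c12` gives 22300 nM (a true number)

Among the measured compounds shown here, compound 2 holds the only true number in this small set, so it is the sole firm reference point. Compound 3 (`COc1ccc(-c2oc3c(OC)c(OC)cc(OCCCCCC(=O)N4CCN(C)CC4)c3c(=O)c2O)cc1`) has not yet been measured. It differs from compound 2 as follows: ((4-methylpiperazin-1-yl)carbonyl)methyl in place of butyl(methyl)carbamoyl on a saturated chain carbon, four bonds along the chain from an oxygen on an aromatic ring (the same change can be read as 2-(butyl(methyl)carbamoyl)ethyl to 3-((4-methylpiperazin-1-yl)carbonyl)propyl).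

For the measured compounds named here, one measured step bears on this: an at least 1.7-fold lower number from compound 1 to compound 2 (0.25 log units; that floor lies within the scatter) (a change that removed a (4-methylpiperazin-1-yl)carbonyl group). Compound 3 brings that amide back, so the step offers a loose guide in the reverse direction, though the chain length differs too. It is only a floor, and a small one, so it supports little. In this assay no change beyond the scatter is expected, and any drift should be toward a higher number, with a 1.3-fold higher number from compound 2 to compound 3 (0.13 log units; within the scatter) as the estimated step. Compound 3 is estimated at 30000 nM (expected range 13000 nM to 65000 nM), and the assay may report only a limit.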

Compound 3, half-maximal inhibitory concentration: 14100 nM
Compound 3: the middle estimate sits 2.1-fold (0.33 log units) above what was measured; measured number inside the range.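

In this assay, keeping the methylpiperazine amide and changing only the length of the chain that carries it gives an at least 2.8-fold lower number from compound 1 to compound 3 (0.45 log units; beyond the scatter), so at this position chain length alone can move the read-out by more than the usual scatter, which the earlier step could not show. That step is a floor and not an exact size, since the value of compound 1 is a limit and not a number: the limit of > 40000 nM in this assay, at which 1 of the 3 values shown sits. The amide swap, which also alters the chain, gives a 1.6-fold lower number from compound 2 to compound 3 (0.20 log units; within the scatter), so the butyl(methyl)carbamoyl and methylpiperazine ends cannot be told apart here, and the piperazine ring shows neither a gain nor a loss in this pair.

Among the compounds shown here, it remains open whether a still longer chain would lower the number further or whether the trend stops, since only a single step beyond the scatter supports it. Also open, from the compounds shown here alone, are how the two amides compare on a chain of identical length, and whether a morpholine amide or a free carboxylic acid at the chain end would do better.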